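Adding a trifluoromethyl group to a weak binder

The compounds below may be only part of what the source reports. "The series", "measured", "known", "first", "only" and "open" are said of these compounds alone.

Of the compounds shown here, three sharing one core have been measured in an assay on isolated protein for binding affinity to adenosine receptor A1 (Bos taurus); a higher number here means a weaker inhibitor, a lower number a stronger inhibitor. Compound 1 `FC(F)(F)c1ccccc1Cn1nnc2c(NC3CCCCC3)nc(-c3ccccc3)nc21` gives 6800000 nM. Compound 2 `c1ccc(Cn2nnc3c(NC4CC4)nc(-c4ccccc4)nc32)cc1` gives 11000000 nM, the highest of the three numbers and so the weakest binding seen here, though its gap to compound 1 is within the scatter. Among the compounds with values here, compound 3 `OC1CCC(Nc2nc(-c3ccccc3)nc3c2nnn3Cc2ccccc2)CC1` gives 2700000 nM, and the change a 4.1-fold lower number from compound 2 to compound 3 (0.61 log units; beyond the scatter) is the only single step measured.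

Compound 4 `FC(F)(F)c1ccccc1Cn1nnc2c(NC3CC3)nc(-c3ccccc3)nc21` is not yet measured. It differs from compound 2 by trifluoromethyl in place of hydrogen on an aromatic carbon. Within the data shown here, no measured step makes this same change on its own: compound 1 carries the trifluoromethyl group but also a different amine, so only its value beside that of compound 2 can be compared, and those two numbers lie within the scatter of each other. There is therefore no basis for expecting a shift beyond the scatter in either direction, and the step of a 1.2-fold lower number from compound 2 to compound 4 (0.09 log units; within the scatter) is an expectation of roughly no change. Compound 4 is estimated at 9000000 nM, with a range from 3000000 nM to 25000000 nM.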

Compound 4, inhibition constant: 7800000 nM
Beside the measured number, compound 4's estimate is 1.2-fold (0.06 log units) above it; the range from low to high includes it.
By their numbers in this assay, from the lowest: compound 3; then compounds 1, 4 and 2 (each within the scatter of the next).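

Within the data shown here, with the step of a 1.4-fold lower number from compound 2 to compound 4 (0.15 log units; within the scatter), this assay gives the first direct reading of trifluoromethyl in place of hydrogen on an aromatic carbon, ortho to a large group, and the two compounds cannot be told apart at this position. The amine can now be read with the trifluoromethyl group in place: the step of a 1.1-fold higher number from compound 1 to compound 4 (0.06 log units; within the scatter), cyclopropyl in place of cyclohexyl, also leaves the two compounds indistinguishable. No measurement offered here explains these results.

As far as these compounds go, it remains open whether a smaller group at the same place, such as a chlorine atom or a methoxy group, would also fall within the scatter of the unsubstituted phenyl. From the compounds shown here alone, it is also open whether the step of a 4.1-fold lower number from compound 2 to compound 3 (0.61 log units; beyond the scatter) would carry over to a compound combining 4-hydroxycyclohexyl with 2-(trifluoromethyl)phenyl.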